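The source may report more compounds than this note shows. Statements on the series, on what has been measured and on what is new or still open speak of the compounds shown alone.

Measured so far:
Compound 1, `Cc1c(OCCCCOc2ccc(C(=O)O)cc2)ccc(C(=O)CC2CCCC2)c1O`, in an assay on HEK293 cells for positive allosteric modulation of metabotropic glutamate receptor 3 (Rattus norvegicus), read by thallium flux, with a stated time of 2.5 min (on this read-out higher numbers stand for an effect only at larger amounts of compound and lower numbers for an effect already at smaller amounts), gives only a limit, > 10000 nM.
Compound 2, `Cc1c(OCCCCOc2ccc(F)c(C(=O)O)c2)ccc(C(=O)CC(C)(C)C)c1O`, in this assay gives 258 nM.
Compound 3, `Cc1c(OCCCCOc2ccc(C(=O)CC(C)(C)C)c(O)c2C)cccc1C(=O)O`, in this assay gives 300 nM.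

Compound 2 holds the lowest of the two numbers; its nearest neighbour is compound 3, with a 1.2-fold higher number from compound 2 to compound 3 (0.07 log units; within the scatter), a change at the carboxyphenyl end of the chain. Compound 4, `Cc1c(OCCCCOc2ccc(F)c(C(=O)O)c2)ccc(C(=O)C(C)C)c1O`, differs from compound 2 at the other end: isopropyl in place of neopentyl on a carbonyl carbon. For the measured compounds named here, no measured step touches this ketone side chain. Compound 1 differs from compound 2 at that side chain and elsewhere, and it sits at a limit, (the limit of > 10000 nM in this assay, at which 1 of the 3 values shown sits). Guidance is therefore thin, and a drift toward a higher number seems somewhat more likely than a lower one. Compound 4 is expected at 600 nM, within a range from 200 nM to 3000 nM. The expected change is a 2.3-fold higher number from compound 2 to compound 4 (0.37 log units; beyond the scatter).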

Compound 4, half-maximal effective concentration: > 10000 nM
Compound 4: no number, only a limit; the forecaster's own chance of this, stated with the estimate: 10%; at least 16-fold (1.22 log units) between middle value and limit.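

In this assay, isopropyl in place of neopentyl on a carbonyl carbon gives an at least 38-fold higher number from compound 2 to compound 4 (1.58 log units; beyond the scatter). Compound 4 gives only a limit, not a number. For the compounds shown here, the earlier step, at the carboxyphenyl end of the chain, was a 1.2-fold higher number from compound 2 to compound 3 (0.07 log units; within the scatter), so this is the first sign that the ketone side chain can matter strongly.

On these data alone, how far the read-out depends on this side chain remains open. A tert-butyl group or a longer chain, such as an n-pentyl chain, on the same carbonyl carbon could show whether neopentyl is unusual.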